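Swapping the Anilide for a Morpholine Amide

The source may hold more compounds than are shown below. What is called first, only, known or untested is meant among the compounds shown, and "the series" means these compounds.

Measured compounds in this assay:
Compound 1 `C=CCc1cc(-c2sc(NC(=O)C(C)(C)C)nc2C)nn1C(=O)Nc1ccc(OC)cc1`: 933 nM
Compound 2 `COc1ccc(NC(=O)n2nc(-c3sc(NC(=O)C(C)(C)C)nc3C)cc2Cc2cc(Cl)ccc2OC)cc1`: 1000 nM
Compound 3 `CN(C)CCN1CCN(c2nc(-c3ccccn3)nc3c2CN(C(=O)c2ccccc2)CC3)CC1`: 100000 nM

All three were tested in an assay on cells with Cystic fibrosis transmembrane conductance regulator variant F508del (Homo sapiens) as the target, read by fluorescence, with stated times of 24 h and 30 min; on this read-out higher numbers stand for an effect only at larger amounts of compound and lower numbers for an effect already at smaller amounts. Compound 2 sits second highest of the three numbers: compound 1 lies within the scatter of it, while compound 3, built on an unrelated core, gives a number far higher. For the measured compounds named here, the only step between two compounds of the shared core, a 1.1-fold higher number from compound 1 to compound 2 (0.03 log units; within the scatter), alters a saturated chain carbon and leaves the carbonyl and its attached amide untouched.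

The step to compound 4 `COc1ccc(Cl)cc1Cc1cc(-c2sc(NC(=O)C(C)(C)C)nc2C)nn1C(=O)N1CCOCC1` touches exactly that part: morpholin-4-yl in place of (4-methoxyphenyl)amino on a carbonyl carbon. Going by the values given here, no measured pair shows this kind of change, so the step from compound 1 to compound 2 tells only that the core tolerates variation at another place, and compound 3 offers no guidance at all. With the amide hydrogen gone and the aromatic ring replaced by a saturated one, a modest weakening seems plausible, but the evidence is thin, so the expected step is a 2.5-fold higher number from compound 2 to compound 4 (0.40 log units; beyond the scatter). Compound 4 is therefore estimated at 2500 nM, with a range from 500 nM to 12000 nM.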

Compound 4, half-maximal effective concentration: 1000 nM
Beside the measured number, compound 4's estimate is 2.5-fold (0.40 log units) above it; measured number inside the range.
By their numbers in this assay, from the lowest: compounds 1, 2 and 4 (each within the scatter of the next); then compound 3.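

In this assay, morpholin-4-yl in place of (4-methoxyphenyl)amino on the carbonyl carbon gives no change at the digits printed from compound 2 to compound 4 (within the scatter). For the compounds shown here, this is the first view of this position, since the earlier step within the shared core changed a saturated chain carbon instead, and it shows that in this pair the read-out stays within the scatter even though the entering group has fewer heavy atoms, no aromatic ring and no hydrogen-bond donor. Nothing available explains why the two groups read alike.

From the compounds shown here alone, it remains open how far this tolerance extends on the carbonyl carbon, as an open-chain amine such as diethylamino or a chain ending in a carboxylic acid might read quite differently from both of these groups. It is also unknown whether the same swap would read alike on the core of compound 1, which carries vinyl on the saturated chain carbon instead of 5-chloro-2-methoxyphenyl.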